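The source may report more compounds than this note shows. Statements on the series, on what has been measured and on what is new or still open speak of the compounds shown alone.

Of the compounds shown here, three have been measured in an assay on isolated protein for binding affinity to Equilibrative nucleoside transporter 1 (Homo sapiens); a lower number here means a stronger inhibitor, a higher number a weaker inhibitor. Compound 2 `OC[C@H]1O[C@@H](n2cnc3c(SCC4CCCCC4)ncnc32)[C@H](O)[C@@H]1O` gives 1550 nM, the lowest of the three numbers. Compound 3 `CCCn1cnc2c(SC(C)C)nc(N)nc21` gives 145000 nM, and compound 1 `Nc1ncnc2c1ncn2[C@@H]1O[C@H](COCCOCCNc2ncnc3c2ncn3[C@@H]2O[C@H](CO)[C@@H](O)[C@H]2O)[C@@H](O)[C@H]1O` gives 912000 nM; both of these gaps to compound 2 lie beyond the usual scatter. Among the measured compounds shown here, no pair of these measured compounds differs in just one place, so no single step can be read from them.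

Compound 4 `OC[C@H]1O[C@@H](n2cnc3c(CSc4ccccc4Cl)ncnc32)[C@H](O)[C@@H]1O` is not yet measured. It differs from compound 2 in one place: ((2-chlorophenyl)sulfanyl)methyl in place of (cyclohexylmethyl)sulfanyl on an aromatic carbon. For the measured compounds named here, the data hold no comparable step. The direction can only be guessed. For compound 4 a modest weakening is expected, a step of a 2.6-fold higher number from compound 2 to compound 4 (0.41 log units; beyond the scatter), giving an estimated 4000 nM with a range from 800 nM to 20000 nM.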

Compound 4, half-maximal inhibitory concentration: 1780 nM
For compound 4 the middle estimate is 2.2-fold (0.35 log units) above the measured one; the range from low to high includes it.
By their numbers in this assay, from the lowest: compounds 2 and 4 (each within the scatter of the next); then compound 3; then compound 1.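

In this assay, putting ((2-chlorophenyl)sulfanyl)methyl in place of (cyclohexylmethyl)sulfanyl gives a 1.1-fold higher number from compound 2 to compound 4 (0.06 log units; within the scatter), so the two compounds cannot be told apart. This position on an aromatic carbon therefore tolerates a six-membered aromatic ring in place of a non-aromatic one, even with the added chlorine and the sulfur placed differently in the group. Nothing available explains this match.

On these data alone, the ring type, chlorine and sulfur placement all differ at once, so their separate contributions stay open. Also open, as far as these compounds go, is how an amine or a carboxylic acid at this position would read.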